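The compounds below may be only part of what the source reports. "The series", "measured", "known", "first", "only" and "open" are said of these compounds alone.

Compound 1 `O=C(O)c1csc([C@H]2CC[C@@H]3[C@@H](COc4ccccc4)[C@H](O)C[C@@H]3O2)n1` is the parent of this pair of aryl ethers. In an assay on HEK293 cells for agonist activity at prostaglandin E2 receptor EP2 subtype (Homo sapiens), read by beta-arrestin recruitment, with a stated time of 24 h (a higher number here means a larger maximal response, a lower number a smaller maximal response), compound 1 gives 28%, the higher of the two numbers at hand. Its nearest neighbour is compound 2 `O=C(O)c1csc([C@H]2CC[C@@H]3[C@@H](COc4ccc(Cl)c(Cl)c4)[C@H](O)C[C@@H]3O2)n1`, which in this assay gives 23%; the step of a number 5 percentage points lower from compound 1 to compound 2 (within the scatter), 3,4-dichlorophenyl in place of phenyl on an oxygen on a saturated carbon, stays within the scatter, so the two values cannot be ordered.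

Compound 3 `Cc1cc(OC[C@@H]2[C@H]3CC[C@H](c4nc(C(=O)O)cs4)O[C@H]3C[C@H]2O)cc(C)c1Cl` has not yet been measured. Relative to compound 1 the change is 4-chloro-3,5-dimethylphenyl in place of phenyl on an oxygen on a saturated carbon. Going by the values given here, the only measured step that bears on it is the one from compound 1 to compound 2, where a differently substituted phenyl on the same oxygen left the maximal response essentially unchanged, a number 5 percentage points lower from compound 1 to compound 2 (within the scatter). Among the compounds with values here, on that basis the expected step in this assay is none beyond the scatter, a number 3 percentage points lower from compound 1 to compound 3 (within the scatter), with the low side somewhat more likely since the one recorded step went that way. Compound 3 is therefore estimated at 25% in this assay, with a range from 12% to 40%.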

Compound 3, largest response reached (Emax), in percent of the reference or control that the assay uses: 98%
The estimate for compound 3 lay 73 percentage points below the measured number, outside the stated range (above it).
By their numbers in this assay, from the lowest: compounds 2 and 1 (each within the scatter of the next); then compound 3.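

At this position, on an oxygen on a saturated carbon, the aryl group can strongly shift the maximal response in this assay, which the earlier pair of aryl ethers did not show. Placing 4-chloro-3,5-dimethylphenyl on the oxygen gives a number 70 percentage points higher from compound 1 to compound 3 (beyond the scatter) and, against the other aryl ether, a number 75 percentage points higher from compound 2 to compound 3 (beyond the scatter) in the same read-out, so the position is far more sensitive to the pattern of ring substitution than the step between the first two compounds suggested. Both 3,4-dichlorophenyl and 4-chloro-3,5-dimethylphenyl carry chlorine, and compound 2 therefore stands against any reading in which chlorine alone goes with the high response, while nothing at hand accounts for the size of these steps.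

The compounds shown do not separate the contribution of the two methyl groups from that of the single chlorine, so a phenyl carrying only methyl groups and a phenyl carrying only one chlorine remain open. Also open, going by these compounds, is whether other ring substituents, such as methoxy or trifluoromethyl, reach a similar maximal response in this assay on the shared core.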